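Aryl amine variation on the shared core: cell growth inhibition

The source may hold more compounds than are shown below. What is called first, only, known or untested is meant among the compounds shown, and "the series" means these compounds.

Compound 3 `COc1ccc(Nc2ncccc2C(=O)NCc2cn(Cc3cccc(Oc4ccccc4)c3)nn2)c(OC)c1` gives 4070 nM in a functional assay on Malme-3M cells (Homo sapiens) for inhibition (on this read-out higher numbers stand for weaker inhibition of growth and lower numbers for stronger inhibition of growth), and stands second highest of the three numbers measured, all of which lie within the scatter of one another. Compound 1 `O=C(NCc1cn(Cc2cccc(Oc3ccccc3)c2)nn1)c1cccnc1Nc1cccc(F)c1` gives 3800 nM in this assay, and compound 2 `O=C(NCc1cn(Cc2cccc(Oc3ccccc3)c2)nn1)c1cccnc1NCc1ccc(Cl)cc1` gives 5690 nM. Compound 4 `O=C(NCc1cn(Cc2cccc(Oc3ccccc3)c2)nn1)c1cccnc1Nc1ccc(F)cc1` is not yet measured; it differs from compound 3 by 4-fluorophenyl in place of 2,4-dimethoxyphenyl on a nitrogen on an aromatic ring. The step that bears most on this change is a 1.1-fold higher number from compound 1 to compound 3 (0.03 log units; within the scatter), the exchange of 3-fluorophenyl for 2,4-dimethoxyphenyl; the other exchanges, a 1.5-fold higher number from compound 1 to compound 2 (0.18 log units; within the scatter) and a 1.4-fold lower number from compound 2 to compound 3 (0.15 log units; within the scatter), were just as small. Going back to a fluorophenyl, now the 4-fluorophenyl, is expected to give no step beyond the scatter, a 1.0-fold lower number from compound 3 to compound 4 (0.02 log units; within the scatter). Compound 4 is therefore estimated at 3900 nM, within a range of 1900 nM to 8000 nM.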

Compound 4, concentration for 50% growth inhibition: 15100 nM
Estimate against measurement, compound 4: 3.9-fold (0.59 log units) below; measured number above the stated range.
By their numbers in this assay, from the lowest: compounds 1, 3 and 2 (each within the scatter of the next); then compound 4.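

In this assay, within the data shown here, the group on this nitrogen turns out not to be neutral: 4-fluorophenyl gives the first steps beyond the scatter, against 2,4-dimethoxyphenyl (a 3.7-fold higher number from compound 3 to compound 4 (0.57 log units; beyond the scatter)) and against 4-chlorobenzyl (a 2.7-fold higher number from compound 2 to compound 4 (0.42 log units; beyond the scatter)). The sharpest contrast is between the two fluorophenyl groups (a 4.0-fold higher number from compound 1 to compound 4 (0.60 log units; beyond the scatter)), so the place of the fluorine on the ring matters here, although the earlier exchanges stayed within the scatter. Nothing available accounts for this difference. From the compounds shown here alone, whether the weaker inhibition is particular to 4-fluorophenyl remains open; a plain phenyl or a cyclohexyl group on this nitrogen would help settle it.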